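The source may hold more compounds than are shown below. What is called first, only, known or untested is meant among the compounds shown, and "the series" means these compounds.

Measured so far:
compound 1, `O=S(=O)(Nc1ccc(-c2nc3ccccc3o2)cc1)c1cccc(O)c1`: > 100000 nM
compound 2, `O=S(=O)(Nc1ccc2oc(-c3ccccc3)nc2c1)c1cccc(O)c1`: > 100000 nM

In an ADME assay on HEK293 cells (Homo sapiens) for cytotoxicity, read by resazurin assay, with a stated time of 48 h (on this read-out higher numbers stand for lower toxicity in this test and lower numbers for higher toxicity in this test), compound 1 gives > 100000 nM, which is a limit of the assay and not a number. In this assay compound 2 also gives only a limit, > 100000 nM. Within the data shown here, compound 1 therefore stands at the edge of what the assay resolves, and the one other value shown sits there as well, as the limit of > 100000 nM in this assay, at which 2 of the 2 values shown sit, records. Among the measured compounds shown here, no step between measured compounds is available, so nothing in the data says how a change on the sulfonyl sulfur moves the read-out.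

Compound 3, `Cc1ccccc1S(=O)(=O)Nc1ccc(-c2nc3ccccc3o2)cc1`, differs from compound 1 by 2-methylphenyl in place of 3-hydroxyphenyl on a sulfonyl sulfur. With both measured values at the limit, the expected step in this assay is none beyond the scatter, which for compound 3 means a number no higher from compound 1 to compound 3 (the limit leaves the size open). Compound 3 is thus estimated at 100000 nM in this assay, with a range from 30000 nM to 300000 nM, and most likely reported again as a limit.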

Compound 3, half-maximal cytotoxic concentration: > 100000 nM
Compound 3: a limit, no number; the forecaster's own chance of this, stated with the estimate: 70%; the middle value sits exactly at the limit.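

In this assay, among these compounds, compound 1 and compound 3 both give only a limit, so no step between them can be read: the limit of > 100000 nM in this assay, at which 3 of the 3 values shown sit.

The compounds shown leave open at what concentration any of them lowers the read-out in this assay and whether 2-methylphenyl in place of 3-hydroxyphenyl changes it.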